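Expected Potency of a Pyridin-3-yl Variant of Compound 3

The compounds below may be only part of what the source reports. "The series", "measured", "known", "first", "only" and "open" are said of these compounds alone.

Measured so far in an assay on Prostate gland for inhibition of steroid 5-alpha-reductase (Rattus norvegicus); on this read-out lower numbers stand for stronger inhibition and higher numbers for weaker inhibition:
Compound 1 `CCCCCC(CCCCC)n1ccc2cc(/C(C)=C/C(=O)Nc3ccccc3OCCCC(=O)O)ccc21` gives 25 nM
Compound 2 `CCCCCC(c1ccccc1)n1ccc2cc(/C(C)=C/C(=O)Nc3ccccc3OCCCC(=O)O)ccc21` gives 25 nM
Compound 3 `C/C(=C\C(=O)Nc1ccccc1OCCCC(=O)O)c1ccc2c(ccn2C(c2ccccc2)C(C)C)c1` gives 25 nM

The three compounds share one core and differ only in the group on the aromatic nitrogen. Compound 3 stands level with compound 1 and compound 2 at the digits shown. The steps of no change at the digits printed from compound 1 to compound 2 (within the scatter), no change at the digits printed from compound 1 to compound 3 (within the scatter) and no change at the digits printed from compound 2 to compound 3 (within the scatter) show that exchanging pentyl for phenyl, or pentyl for isopropyl, at this position left the read-out unchanged within the scatter.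

Compound 4 `C/C(=C\C(=O)Nc1ccccc1OCCCC(=O)O)c1ccc2c(ccn2C(c2ccccc2)c2cccnc2)c1` carries pyridin-3-yl in place of isopropyl on a saturated chain carbon bound to an aromatic carbon and an aromatic nitrogen. Each of the three measured steps bears on it, since each alters the same position, and none moved the number beyond the scatter. A step of no change at the digits printed from compound 3 to compound 4 (within the scatter) is therefore expected for compound 4, that is, no change beyond the scatter. Compound 4 is estimated at 25 nM in this assay, with a range from 10 nM to 70 nM.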

Compound 4, half-maximal inhibitory concentration: 47 nM
Estimate against measurement, compound 4: 1.9-fold (0.27 log units) below; the measured number falls inside the stated range.
By their numbers in this assay, from the lowest: compounds 1, 2, 3 and 4 (each within the scatter of the next).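

Pyridin-3-yl is the first group at this place shown to hold an atom other than carbon, bringing one ring nitrogen and one hydrogen-bond acceptor, yet in this assay exchanging isopropyl for it gives a 1.9-fold higher number from compound 3 to compound 4 (0.27 log units; within the scatter) and exchanging pentyl for it gives a 1.9-fold higher number from compound 2 to compound 4 (0.27 log units; within the scatter). The earlier compounds had shown only that groups made of carbon and hydrogen could be exchanged here without a change beyond the scatter. Across these four compounds, that now also holds for a six-membered aromatic ring with a hetero atom.

From the compounds shown here alone, whether an amine, a carboxylic acid or a pyridin-2-yl group on this saturated chain carbon would also leave the number within the scatter stays open. No supporting measurement bearing on this result is at hand.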